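Working notes: lengthening the chain of compound 1

A few compounds are considered here, and "the series" means these few. Any claim that something is new, unique, unknown or untested is made for them only; others in the source may bear on it.

compound 1 `CCCCCCCCCCCCCC[C@@H](O)[C@@H](O)[C@H](CO)n1cc(CCC)nn1` gives 13900 nM
compound 2 `CCCCCCCCCCCCC/C=C/[C@@H](O)[C@H](CO)n1cc(CCCCCCCCCCCCC)nn1` gives > 50000 nM as a limit
compound 3 `CCCCCCCCCCCCC/C=C/[C@@H](O)[C@H](CO)n1cc(CCCCCC)nn1` gives 12500 nM

All of these values come from a functional assay on HCT-116 cells (Homo sapiens) for cytotoxicity, read by sulforhodamine B assay (on this read-out lower numbers stand for an effect already at smaller amounts and higher numbers for an effect only at larger amounts of compound), as the read-out. Compound 1 and compound 3 lie within the scatter of each other. Among the compounds with values here, the value of compound 2 is a limit, not a number, so compound 1 has only one true numerical neighbour.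

Compound 4 `CCCCCCCCCCCCCC[C@@H](O)[C@@H](O)[C@H](CO)n1cc(CCCCCCCCCCCCC)nn1` keeps the core of compound 1 and changes it by decyl in place of hydrogen on a saturated chain carbon, three bonds along the chain from an aromatic carbon.

Within the data shown here, one measured step bears on this change (an at least 4.0-fold lower number from compound 2 to compound 3 (0.60 log units; beyond the scatter)). It lies beyond the scatter, and it shortens a chain, so the lengthening here is read in the opposite direction. Its size is only a bound, and it comes from a single pair on a core that differs from that of compound 1. A step towards higher numbers in this assay is therefore expected, and compound 4 may well end at the limit of > 50000 nM in this assay, at which 1 of the 3 values shown sits, as well. The expected outcome is a 2.9-fold higher number from compound 1 to compound 4 (0.46 log units; beyond the scatter) in this read-out. The estimated value for compound 4 is 40000 nM (expected range 14000 nM to 100000 nM).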

Compound 4, half-maximal effective concentration: > 50000 nM
Compound 4 gave a limit, no number; the forecaster's own chance of this, stated with the estimate: 55%; at least 1.2-fold (0.09 log units) between middle value and limit.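

On the core of compound 1, decyl in place of hydrogen on a saturated chain carbon, three bonds along the chain from an aromatic carbon, gives an at least 3.5-fold higher number from compound 1 to compound 4 (0.55 log units; beyond the scatter) in this assay. The direction of this change therefore no longer rests on a single pair on another core, since an at least 4.0-fold lower number from compound 2 to compound 3 (0.60 log units; beyond the scatter) reads the same way once it is taken in reverse, and both steps lie beyond the scatter. The value of compound 4, > 50000 nM, is a limit, so the size of this step is only a bound, and compound 2 and compound 4, the two compounds with the long chain, now sit together: the limit of > 50000 nM in this assay, at which 2 of the 4 values shown sit.

With limits at the long end, the compounds shown do not tell how far the numbers rise, nor at which chain length on the core of compound 1 the rise sets in, and a chain such as octyl would bear directly on that. Also open, on these data alone, is whether an amine or a carboxylic acid in place of decyl at this same place would hold the number of compound 1 in this read-out or move it.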